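Swapping the amide headgroup of a picomolar p300 inhibitor

The source may report more compounds than this note shows. Statements on the series, on what has been measured and on what is new or still open speak of the compounds shown alone.

Three compounds have numbers in an assay on isolated protein for inhibition of histone acetyltransferase p300 (Homo sapiens), with a stated time of 60 min; a higher number here means a weaker inhibitor, a lower number a stronger inhibitor. Compound 1 `O=C(Nc1ccc2[nH]ccc2n1)[C@H]1CCCN1C(=O)C1(c2cccc(Cl)c2)CCCC1` gives 0.159 nM. Compound 2 `COc1ccc(C2(C(=O)N3CCC[C@@H]3C(=O)Nc3ccc4[nH]ncc4n3)CCC2)cc1` gives 0.251 nM, which lies within the scatter of compound 1, so the two cannot be told apart. Compound 3 `COc1ccc(NC(=O)[C@H]2CCCN2C(=O)C2(c3ccc(Cl)cc3)CCCCC2)cc1` gives 20 nM, a number far beyond the scatter from compound 1; compound 3 differs from compound 1 in several places at once, so the pair shows only that large shifts are possible in this series.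

Compound 4 `CNC(=O)c1cccc(NC(=O)[C@H]2CCCN2C(=O)C2(c3cccc(Cl)c3)CCCC2)c1` differs from compound 1 in one place: a group of 10 heavy atoms (8 carbon, 1 nitrogen, 1 oxygen; one six-membered aromatic ring of carbon only) in place of a group of 9 heavy atoms (7 carbon, 2 nitrogen; one five-membered aromatic ring with 1 hetero atom, one six-membered aromatic ring with 1 hetero atom), on an amide-type nitrogen. Going by the values given here, no measured pair in this set isolates such a change. The expectation for compound 4 is a move toward a higher number, estimated as a 31-fold higher number from compound 1 to compound 4 (1.50 log units; beyond the scatter). This expected shift stops short of the number measured for compound 3, 20 nM. Compound 4 is therefore expected to give about 5 nM, with a likely range from 0.5 nM to 50 nM.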

Compound 4, half-maximal inhibitory concentration: 1260 nM
Compound 4: the middle estimate sits 250-fold (2.40 log units) below what was measured; the whole stated range lies below it.
By their numbers in this assay, from the lowest: compounds 1 and 2 (each within the scatter of the next); then compound 3; then compound 4.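

In this assay, replacing the two-ring group on the amide-type nitrogen with 3-(methylcarbamoyl)phenyl gives a 7900-fold higher number from compound 1 to compound 4 (3.90 log units; beyond the scatter). Going by these compounds alone, this shows that a change in this one place can by itself produce a very large shift, which no earlier pair could show, as none of them differed in only one place. The entering and leaving groups each count one hydrogen-bond donor and one hydrogen-bond acceptor, so those counts alone do not predict the outcome in this pair, and nothing measured here says why the number moves so far.

From the compounds shown here alone, it remains open whether the shift comes from losing the two-ring group or from adding the methylcarbamoyl group, a question that a plain phenyl on the same nitrogen could help separate. Going by these compounds, it is also open whether the same swap on compound 2 would give a shift of similar size.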